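Swapping a Fluorophenyl for an Indazole: Expected Solubility

The source may report more compounds than this note shows. Statements on the series, on what has been measured and on what is new or still open speak of the compounds shown alone.

Measured compounds:
compound 1 `CNC(=O)c1ccc(=O)n(Cc2cc(Br)ccc2F)c1` gives >= 143 ug/mL in a physicochemical assay for solubility; a higher number here means a more soluble compound, a lower number a less soluble compound
compound 2 `CNC(=O)c1cc(C(=O)NC2CC2)cn(Cc2cccc(F)c2)c1=O` gives >= 133 ug/mL in this assay
compound 3 `CNC(=O)c1cc(C(=O)NC(C)C)cn(Cc2ccccc2)c1=O` gives >= 136 ug/mL in this assay

Each of these three readings is a limit of the assay, not a number. Compound 2 stands at the limit of >= 133 ug/mL in this assay, at which 1 of the 3 values shown sits, so only the edge of its solubility is known. Compound 1 rests at the limit of >= 143 ug/mL in this assay, at which 1 of the 3 values shown sits. Compound 3 rests at the limit of >= 136 ug/mL in this assay, at which 1 of the 3 values shown sits.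

Compound 4 `CNC(=O)c1cc(C(=O)NC2CC2)cn(Cc2cccc3[nH]ncc23)c1=O` differs from compound 2 by 1H-indazol-4-yl in place of 3-fluorophenyl on a saturated chain carbon bound to an aromatic nitrogen. Among the measured compounds shown here, no measured pair shows what this exchange does to solubility. In this assay the step is expected to stay within the scatter, and the estimated step of an at least 1.1-fold lower number from compound 2 to compound 4 (0.04 log units; that floor lies within the scatter) is therefore small. Compound 4 is expected to give 120 ug/mL, with a range from 40 ug/mL to 200 ug/mL, most likely again reported as a limit.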

Compound 4, solubility: 10 ug/mL
Beside the measured number, compound 4's estimate is 12-fold (1.08 log units) above it; measured number outside the range, below it.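

On a saturated chain carbon bound to an aromatic nitrogen, the choice of ring system can matter greatly in this assay: 1H-indazol-4-yl in place of 3-fluorophenyl gives an at least 13-fold lower number from compound 2 to compound 4 (1.12 log units; beyond the scatter). The reading of compound 2 is a limit of the assay, >= 133 ug/mL, so this step marks only the smallest possible change. Among the compounds shown here, compound 4 is also the first compound here with a plain number rather than a limit. The compounds shown give no cause for this fall. Also open, going by these compounds, is whether an amine or a carboxylic acid on the 1H-indazol-4-yl group would raise the reading again.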